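This account rests on a few compounds, and the source may have more. Where it says the series, first, only, none or still open, it means among the compounds named here.

Of the compounds shown here, three of a shared core have been tested in a functional assay on PC-3 cells (Homo sapiens) for antiproliferative activity, read by MTT assay, with a stated time of 48 h; a higher number here means a weaker inhibitor, a lower number a stronger inhibitor. Compound 1 `O=C(/C=C\Nc1ccc(Cl)cc1)c1cn(-c2ccccc2)nc1-c1ccc(F)cc1` gives 3800 nM, and compound 2 `O=C(/C=C\Nc1ccc(Cl)cc1)c1cn(-c2ccccc2)nc1-c1ccc(Cl)cc1` gives 3890 nM; the two differ only in a 1.0-fold higher number from compound 1 to compound 2 (0.01 log units; within the scatter). Compound 3 `COc1ccc(-c2nn(-c3ccccc3)cc2C(=O)/C=C\Nc2ccc(F)cc2)cc1` gives 5730 nM, the highest of the three numbers, although its distance to compound 2 and to compound 1 stays within the scatter, so no order among the three can be drawn.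

Compound 4 `COc1ccc(-c2nn(-c3ccccc3)cc2C(=O)/C=C\Nc2ccc(Cl)cc2)cc1` has not yet been measured in this assay. It differs from compound 3 in one place: chloro in place of fluoro on an aromatic carbon. For the measured compounds named here, the single measured step that bears on it, from compound 1 to compound 2, is the same exchange of halogen on an aromatic carbon, though on a different ring of the core, and that step read as no change beyond the scatter. On that basis the exchange in compound 4 is expected to leave the number close to where compound 3 stands, and the expected step of a 1.0-fold lower number from compound 3 to compound 4 (0.02 log units; within the scatter) is taken as one of no meaningful size in either direction. The estimate for compound 4 in this assay is therefore 5500 nM, with a range from 2700 nM to 11000 nM.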

Compound 4, half-maximal inhibitory concentration: 3890 nM
Compound 4: the middle estimate sits 1.4-fold (0.15 log units) above what was measured; the range from low to high includes it.
By their numbers in this assay, from the lowest: compounds 1, 2, 4 and 3 (each within the scatter of the next).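

In this assay, chloro in place of fluoro at the (4-fluorophenyl)amino group gives a 1.5-fold lower number from compound 3 to compound 4 (0.17 log units; within the scatter), so with methoxy on the other aromatic ring this exchange also stays inside the scatter. The second place of variation can now be read with the (4-chlorophenyl)amino group held constant: there is no change at the digits printed from compound 2 to compound 4 (within the scatter) and a 1.0-fold higher number from compound 1 to compound 4 (0.01 log units; within the scatter), so methoxy, chloro and fluoro at that place cannot be told apart in this assay. The halogen exchange has now been read in two settings, and the two readings agree within the scatter of such steps: the same change on two cores in this assay, a 1.0-fold higher number (0.01 log units; within the scatter) from compound 1 to compound 2 and a 1.5-fold lower number (0.17 log units; within the scatter) from compound 3 to compound 4, 1.5-fold (0.18 log units) apart, within the scatter of two such steps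

Every step among these compounds lies within the scatter, so they leave open whether any substituent at the position para to the large group can move the number at all, for example a dimethylamino group, a carboxylic acid or a longer chain such as butoxy in place of the chloro. They also leave open whether the unsubstituted phenyl group, with only hydrogen at that position, would read any differently from the halogen-bearing compounds.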